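Swapping the anilino arm of compound 2 for a piperidinyloxy group

The source may hold more compounds than are shown below. What is called first, only, known or untested is meant among the compounds shown, and "the series" means these compounds.

Compound 1 `CNc1cc(Nc2ncc3c(n2)N(C)C(=O)N(c2cc(NC(=O)c4cccc(C(F)(F)F)c4)ccc2C)C3)ccc1C` gives 19 nM in a functional assay on K562 cells (Homo sapiens) for antiproliferative activity, read by CellTiter-Glo and CCK-8 assay, with a stated time of 72 h; a higher number here means a weaker inhibitor of growth, a lower number a stronger inhibitor of growth.
Compound 2 `Cc1ccc(Nc2ncc3c(n2)N(C)C(=O)N(c2cc(NC(=O)c4cccc(C(F)(F)F)c4)ccc2C)C3)cc1N` gives 3 nM in this assay.

Compound 2 stands at the lowest of the two numbers, and its nearest neighbour is compound 1, which is separated from it by a step of a 6.3-fold lower number from compound 1 to compound 2 (0.80 log units; beyond the scatter), a step beyond the usual scatter. Compound 3 `Cc1ccc(NC(=O)c2cccc(C(F)(F)F)c2)cc1N1Cc2cnc(OC3CCNCC3)nc2N(C)C1=O` has not yet been measured. It differs from compound 2 in one place: (piperidin-4-yl)oxy in place of (3-amino-4-methylphenyl)amino on an aromatic carbon. Within the data shown here, the only measured step, from compound 1 to compound 2, also touches this region of the molecule, but it altered a single nitrogen substituent on the group that now leaves entirely, so it bears on the new change only loosely. That step shows this part of the structure is sensitive to change; since in compound 3 the whole arm is exchanged for a different kind of group, a step at least as large, toward a higher number, is expected, namely a 20-fold higher number from compound 2 to compound 3 (1.30 log units; beyond the scatter). For compound 3 the expected value in this assay is therefore 60 nM, with a likely range from 10 nM to 400 nM.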

Compound 3, concentration for 50% growth inhibition: 220 nM
Compound 3: the middle estimate sits 3.7-fold (0.56 log units) below what was measured; the range from low to high includes it.
By their numbers in this assay, from the lowest: compound 2; then compound 1; then compound 3.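

The position on the aromatic carbon between two ring nitrogen atoms accepts a complete exchange of its group with growth inhibition still measurable, but at a clear cost: in this assay the change to (piperidin-4-yl)oxy gives a 73-fold higher number from compound 2 to compound 3 (1.87 log units; beyond the scatter). The same exchange starting from the (4-methyl-3-(methylamino)phenyl)amino arm gives a 12-fold higher number from compound 1 to compound 3 (1.06 log units; beyond the scatter), so the rise appears with either of the two arms as the starting point, and both steps are larger than the small edit on the arm's nitrogen, a 6.3-fold lower number from compound 1 to compound 2 (0.80 log units; beyond the scatter). Nothing measured here explains the rise.

As far as these compounds go, this exchange alters the ring and its link together: an aromatic ring attached through nitrogen leaves, and a non-aromatic ring attached through oxygen enters, so the share of each in the step stays open. A (piperidin-4-yl)amino group, which pairs the new ring with the old nitrogen link, and a phenoxy group, which pairs an aromatic ring with the new oxygen link, would tell these two parts of the change apart.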